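Formyl for (ethoxycarbonyl)amino on the shared core

The source may hold more compounds than are shown below. What is called first, only, known or untested is meant among the compounds shown, and "the series" means these compounds.

Measured so far:
compound 1 `NC(=O)COc1cc(=O)oc2cc(OCc3cccc(Cl)c3)ccc12` — 3.1 nM; 3.31 nM (2 entries)
compound 2 `CCOC(=O)Nc1cc(=O)oc2cc(OCc3cccc(Cl)c3)ccc12` — 589 nM

Two compounds of the series have numbers in an assay on isolated protein (strain Sprague-Dawley) for inhibition of Amine oxidase [flavin-containing] B (Rattus norvegicus), read by spectrophotometry, with a stated time of 5 min; on this read-out lower numbers stand for stronger inhibition and higher numbers for weaker inhibition. Compound 1 has several entries in this assay, all close to each other (the several entries of compound 1 in this assay, 3.1 nM; 3.31 nM (2 entries)). Among the compounds with values here, compound 2 in this assay gives 589 nM; that is the only number reported for it, and a further entry carries no single number. Within the data shown here, no pair among the measured compounds differs in one place, so no measured step is available.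

Compound 3 `O=Cc1cc(=O)oc2cc(OCc3cccc(Cl)c3)ccc12` is not yet measured. Compared with compound 2 it carries a change on the core: formyl in place of (ethoxycarbonyl)amino on an aromatic carbon

Without a measured step to lean on, only a rough expectation is possible. The formyl group is much smaller than the (ethoxycarbonyl)amino group it replaces and drops the hydrogen-bond donor. The expectation is a modest move toward stronger inhibition, small enough that it could still fall within the usual scatter. The step from compound 2 to compound 3 is expected to be a 2.4-fold lower number from compound 2 to compound 3 (0.37 log units; beyond the scatter). In this assay compound 3 is estimated at 250 nM, with a plausible range from 40 nM to 1500 nM.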

Compound 3, half-maximal inhibitory concentration: 52.5 nM
The estimate for compound 3 lay 4.8-fold (0.68 log units) above the measured number; the measured number falls inside the stated range.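

Within the data shown here, replacing (ethoxycarbonyl)amino with formyl on the aromatic carbon opposite the ring oxygen gives an 11-fold lower number from compound 2 to compound 3 (1.05 log units; beyond the scatter) in this assay, the first step that can be read at a single place. The position is therefore not indifferent to what it carries, and the (ethoxycarbonyl)amino group, with its hydrogen-bond donor, is not required for inhibition in this assay, since the smaller formyl group gives the lower number. Entries for a single compound in this assay lie close together, which supports reading a step of this size as a real difference and says nothing about its cause: the several entries of compound 1 in this assay, 3.1 nM; 3.31 nM (2 entries)

This step changes the heavy atom count, the hydrogen-bond donor and the hydrogen-bond acceptors all at once, so it cannot show which of these differences accounts for the lower number. On these data alone, a plain amine, which keeps a donor, or an acetyl group, which keeps a carbonyl without a donor, on the same aromatic carbon would bear on that question, and how either would read in this assay remains open.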